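From a Hydroxy Group to Chlorine on the Aryl Ketone

This account rests on a few compounds, and the source may have more. Where it says the series, first, only, none or still open, it means among the compounds named here.

Compound 1 `COc1ccc(C(=O)/C=C/c2cc3ccccc3[nH]c2=O)cc1` and compound 2 `O=C(/C=C/c1cc2ccccc2[nH]c1=O)c1ccc(O)cc1` share one core and differ only at a single oxygen. In a functional assay on OVCAR-3 cells (Homo sapiens) for cytotoxicity, read by sulforhodamine B assay, with a stated time of 24 h (a higher number here means a weaker inhibitor of growth, a lower number a stronger inhibitor of growth), compound 1 gives 6720 nM, and compound 2 gives 11800 nM, the higher of the two numbers, although the step of a 1.8-fold higher number from compound 1 to compound 2 (0.24 log units; within the scatter) lies within the scatter. Compound 3 `O=C(/C=C/c1cc2ccccc2[nH]c1=O)c1ccc(Cl)cc1` brings (chloro in place of hydroxy on an aromatic carbon). Among the measured compounds shown here, no measured step exchanges a hydroxy for a chloro, so the one available step, a 1.8-fold higher number from compound 1 to compound 2 (0.24 log units; within the scatter), shows only that altering this oxygen moved the number little. For compound 3 in this assay the expected step is a 1.7-fold lower number from compound 2 to compound 3 (0.23 log units; within the scatter), toward a somewhat lower number, and its value is estimated at 7000 nM, with a range from 2500 nM to 20000 nM.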

Compound 3, concentration for total growth inhibition: 30900 nM
For compound 3 the middle estimate is 4.4-fold (0.64 log units) below the measured one; measured number outside the range, above it.
By their numbers in this assay, from the lowest: compounds 1 and 2 (each within the scatter of the next); then compound 3.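

On this aromatic carbon, the choice of group does register in this assay: chloro in place of hydroxy gives a clear rise (a 2.6-fold higher number from compound 2 to compound 3 (0.42 log units; beyond the scatter)), and chloro in place of methoxy gives a similar one (a 4.6-fold higher number from compound 1 to compound 3 (0.66 log units; beyond the scatter)). Compound 3 is thus the weaker inhibitor of growth beside either compound with oxygen at this place, a separation that altering the oxygen alone did not reveal. Nothing available accounts for this separation. Going by these compounds, whether the loss belongs to chlorine specifically remains open. An amine, a carboxylic acid or a bromo group here could show whether such groups fall with chloro or with hydroxy and methoxy.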